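The compounds below may be only part of what the source reports. "The series", "measured", "known", "first", "only" and "open" are said of these compounds alone.

Measured compounds:
compound 1, `Cc1ccc(CNc2ncnc3c2ncn3[C@@H]2O[C@H](CO)[C@@H](O)[C@H]2O)cc1`: "not determined" (no result reported)
compound 2, `OC[C@H]1O[C@@H](n2cnc3c(NCc4ccc(F)cc4Cl)ncnc32)[C@H](O)[C@@H]1O`: > 166000 nM

In a functional assay on B16 cells (Mus musculus) for antiproliferative activity, with a stated time of 72 h (a higher number here means a weaker inhibitor, a lower number a stronger inhibitor), compound 1 has no reported number. For compound 2 this assay gives a limit, > 166000 nM, not a number; this is the limit of > 166000 nM in this assay, at which 1 of the 2 values shown sits. Compound 3, `COc1cccc(CNc2ncnc3c2ncn3[C@@H]2O[C@H](CO)[C@@H](O)[C@H]2O)c1O`, differs from compound 1 by 2-hydroxy-3-methoxyphenyl in place of 4-methylphenyl on a saturated chain carbon bound to a nitrogen on an aromatic ring. Among the measured compounds shown here, no step between two numbered values exists in this assay, so the size and direction of the step from compound 1 to compound 3 cannot be read off; the expectation rests on the limit of compound 2 alone. Compound 3 is estimated at 100000 nM, with a range of 20000 nM to 300000 nM, and a real chance that only a limit is reported.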

Compound 3, half-maximal inhibitory concentration: > 166000 nM
Compound 3: only a limit was reported; the forecaster's own chance of this, stated with the estimate: 55%; middle value at least 1.6-fold (0.22 log units) from the limit.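

Among the compounds shown here, compound 2 and compound 3 each give only a limit in this assay, and compound 1 has no reported number, so no step to compound 3 can be read. The compounds shown leave open which group on the shared core, if any, would give an actual number in this assay.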